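This account rests on a few compounds, and the source may have more. Where it says the series, first, only, none or still open, it means among the compounds named here.

Of the compounds shown here, three built on a shared core have been measured in an assay on microsomes for inhibition of 3-hydroxy-3-methylglutaryl-coenzyme A reductase (Rattus norvegicus); a higher number here means a weaker inhibitor, a lower number a stronger inhibitor. Compound 1 `CCCCCCCCc1c(-c2ccccc2)sc(C(C)C)c1/C=C/[C@@H](O)C[C@@H](O)CC(=O)O` gives only a limit of the assay, > 10000 nM. Compound 2 `CC(C)c1sc(-c2ccccc2)c(C2CCCC2)c1/C=C/[C@@H](O)C[C@@H](O)CC(=O)O` gives 417 nM, and compound 3 `CC(C)c1sc(-c2ccccc2)c(-c2cccc(C(F)(F)F)c2)c1/C=C/[C@@H](O)C[C@@H](O)CC(=O)O` gives 2980 nM, the higher of the two numbers; the step of a 7.1-fold higher number from compound 2 to compound 3 (0.85 log units; beyond the scatter) separates them, while an at least 3.3-fold lower number from compound 1 to compound 3 (0.52 log units; beyond the scatter) carries compound 3 away from the limit. Compound 4 `CC(C)c1sc(-c2ccccc2)c(-c2cccc(F)c2)c1/C=C/[C@@H](O)C[C@@H](O)CC(=O)O` has not been measured; it differs from compound 3 by fluoro in place of trifluoromethyl on an aromatic carbon. The measured steps show that the group on this aromatic carbon moves the number beyond the scatter, and a lower number is expected for compound 4 because compound 2, bearing cyclopentyl, gives 417 nM. The expected step is a 2.0-fold lower number from compound 3 to compound 4 (0.30 log units; within the scatter). Compound 4 is therefore estimated at 1500 nM, within 500 nM to 5000 nM.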

Compound 4, half-maximal inhibitory concentration: 49 nM
The estimate for compound 4 lay 31-fold (1.49 log units) above the measured number, and the stated range ends above it.
By their numbers in this assay, from the lowest: compound 4; then compound 2; then compound 3. At a limit, above all of these: compound 1.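

In this assay, changing only the substituent on the six-membered aromatic ring gives a 61-fold lower number from compound 3 to compound 4 (1.78 log units; beyond the scatter), so this one group, and not the presence of an aromatic ring alone, governs the number. The ring can also outdo cyclopentyl, with an 8.5-fold lower number from compound 2 to compound 4 (0.93 log units; beyond the scatter), reversing the order seen with compound 3. The step of an at least 200-fold lower number from compound 1 to compound 4 (2.30 log units; beyond the scatter) is only a bound, set against a limit: the limit of > 10000 nM in this assay, at which 1 of the 4 values shown sits.

As far as these compounds go, it remains open whether fluoro itself lowers the number or trifluoromethyl raises it. A plain phenyl, or a chlorine or methoxy group on the same carbon, would separate these readings.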